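The source may hold more compounds than are shown below. What is called first, only, known or untested is meant among the compounds shown, and "the series" means these compounds.

Working notes on the series

Among the measured compounds shown here, compound 2 `COc1cc(Cl)cc(-c2nn(-c3cccc(NC(=O)Nc4cccc(C(F)(F)F)c4)c3)cc2-c2ccncc2)c1` carries the highest of the two numbers so far recorded in a functional assay on SK-OV-3 cells (Homo sapiens) for inhibition, read by sulforhodamine B assay, with a stated time of 48 h, tested at 1 uM (a lower number here means a stronger effect, a higher number a weaker effect of the compound at the concentration tested), where compound 2 gives 103%. Its nearest neighbour is compound 1 `COc1cc(Cl)cc(-c2nn(-c3cccc(NC(=O)Nc4ccc(Cl)c(C(F)(F)F)c4)c3)cc2-c2ccncc2)c1`, which in this assay gives 100%; the step of a number 3 percentage points higher from compound 1 to compound 2 (within the scatter) stays within the scatter.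

Compound 3 `COc1cc(Cl)cc(-c2nn(-c3cccc(NC(=O)c4cccc(C(F)(F)F)c4)c3)cc2-c2ccncc2)c1` is the next member to be measured. Relative to compound 2 the change is 3-(trifluoromethyl)phenyl in place of (3-(trifluoromethyl)phenyl)amino on a carbonyl carbon whose other neighbour is an amide-type nitrogen. For the measured compounds named here, the single measured step, a number 3 percentage points higher from compound 1 to compound 2 (within the scatter), touches a different position and does not bear on this change, so no measured comparison is available for it. Both measured compounds sit close together in this assay. For compound 3 a step of a number 5 percentage points lower from compound 2 to compound 3 (within the scatter) is expected, that is, no shift beyond the scatter. Compound 3 is therefore estimated at 98% in this assay, with a range of 85% to 110%.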

Compound 3, a percentage reported as activity, at one concentration (the size of the read-out at that concentration, not a potency): 99%
The estimate for compound 3 lay 1 percentage points below the measured number; the range from low to high includes it.
By their numbers in this assay, from the lowest: compounds 3, 1 and 2 (each within the scatter of the next).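

Among the compounds shown here, this is the first change at the carbonyl carbon rather than on the outer aromatic ring: in this assay, 3-(trifluoromethyl)phenyl in place of (3-(trifluoromethyl)phenyl)amino gives a number 4 percentage points lower from compound 2 to compound 3 (within the scatter). Against the chloro-bearing group the picture is the same, with a number 1 percentage points lower from compound 1 to compound 3 (within the scatter), so losing the amino nitrogen and its hydrogen-bond donor leaves this read-out within the scatter at the single concentration tested. No measurement to hand offers an explanation for this result.

From the compounds shown here alone, the three compounds are not separated in this read-out, so it remains unknown whether this position can influence it at all under these conditions. Also open, going by these compounds, is whether an amine or a carboxylic acid in place of 3-(trifluoromethyl)phenyl on this carbonyl carbon would shift the number beyond the scatter.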